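The source may report more compounds than this note shows. Statements on the series, on what has been measured and on what is new or still open speak of the compounds shown alone.

Two compounds of the series carry numbers in a functional assay on SK-MEL-5 cells (Homo sapiens) for inhibition, read by sulforhodamine B assay, with a stated time of 48 h; on this read-out lower numbers stand for stronger inhibition of growth and higher numbers for weaker inhibition of growth. Compound 1, `O=C(Nc1ccccc1OC(F)(F)F)Nc1n[nH]c2ccccc12`, gives 28700 nM in this assay. Compound 2, `Nc1nn(C(=O)Nc2ccc(Cc3ccccc3)cc2)c2ccccc12`, gives 2220 nM in this assay, the lowest of the two numbers; the gap between compound 2 and compound 1 lies beyond the usual scatter, so compound 2 stands as the stronger of the pair. Compound 3, `CCCCOc1ccc(NC(=O)n2nc(N)c3ccccc32)cc1`, has not yet been measured in this assay. It differs from compound 2 in one place: butoxy in place of benzyl on an aromatic carbon, para to a large group. For the measured compounds named here, no measured pair shows this exchange, so the size of the step is open. The expected step, a 1.6-fold higher number from compound 2 to compound 3 (0.20 log units; within the scatter), is small, toward weaker inhibition of growth or none beyond the scatter. Compound 3 is estimated at 3500 nM in this assay, with a range from 1200 nM to 11000 nM.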

Compound 3, concentration for 50% growth inhibition: 15200 nM
Compound 3: middle estimate off by 4.3-fold (0.64 log units), on the low side; the measured number lies above the stated range.
By their numbers in this assay, from the lowest: compound 2; then compounds 3 and 1 (each within the scatter of the next).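

In this assay the position on the aromatic carbon, para to a large group, does not treat these two groups alike: butoxy in place of benzyl gives a 6.8-fold higher number from compound 2 to compound 3 (0.84 log units; beyond the scatter) and so weakens inhibition of growth. At this position, the open butoxy chain with its one hydrogen-bond acceptor is therefore no equal replacement for benzyl with its six-membered aromatic ring. Nothing at hand accounts for this loss.

The compounds shown do not separate the loss of the ring from the entry of the oxygen, and a phenoxy or a pentyl group on the same carbon would bear on that question. Going by these compounds, how a shorter chain such as methoxy, or an amine, would fare at this position also remains open.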